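From a Chloropropyl Chain to an Imidazole Tail

A few compounds are considered here, and "the series" means these few. Any claim that something is new, unique, unknown or untested is made for them only; others in the source may bear on it.

Compound 2 `Cn1c(=O)c2[nH]c(-c3ccc(OCCCCl)cc3)nc2n(C)c1=O` was tested in an assay on CHO cells for binding affinity to adenosine receptor A2b (Homo sapiens), with a stated time of 20 min; on this read-out higher numbers stand for weaker inhibition and lower numbers for stronger inhibition. In this assay compound 2 gives only a limit, > 10 nM, not a measured number. Compound 1 `Cn1c(=O)c2[nH]c(Cc3ccc(OCCCn4ccnc4)cc3)nc2n(C)c1=O`, a close relative carrying the same imidazole tail, likewise gives only a limit in this assay, > 10 nM. Both values therefore sit at the limit of > 10 nM in this assay, at which 2 of the 2 values shown sit. Compound 3 `Cn1c(=O)c2[nH]c(-c3ccc(OCCCn4ccnc4)cc3)nc2n(C)c1=O` differs from compound 2 by 1H-imidazol-1-yl in place of chloro on a saturated chain carbon, three bonds along the chain from an oxygen on an aromatic ring. For the measured compounds named here, no measured step guides this change, so the step from compound 2 to compound 3 is expected to be small, a step that the limit leaves unreadable from compound 2 to compound 3, and likely within the scatter. Compound 3 is estimated at 50 nM, with a range from 10 nM to 500 nM.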

Compound 3, inhibition constant: 1.05 nM
Compound 3: the middle estimate sits 48-fold (1.68 log units) above what was measured, outside the stated range (below it).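

In this assay, placing 1H-imidazol-1-yl on the chain instead of chloro gives an at least 9.5-fold lower number from compound 2 to compound 3 (0.97 log units; beyond the scatter), so the group at this chain end clearly affects the read-out. Compound 2 gives only a limit, so this step is a minimum: the limit of > 10 nM in this assay, at which 2 of the 3 values shown sit. Compound 1, which carries the same imidazole tail on a different core, also gives only a limit, > 10 nM.

Going by these compounds, what remains open is whether the imidazole ring itself is needed, or whether a simple amine such as dimethylamino would serve at this chain end. The effect of a carboxylic acid or a longer chain there is also unknown.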